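Adding a 3-chlorophenylcarbonyl group to a hydroxyphenyl amide

The compounds below may be only part of what the source reports. "The series", "measured", "known", "first", "only" and "open" are said of these compounds alone.

Measured compounds and their numbers in a functional assay on NCI-H23 cells (Homo sapiens) for cytotoxicity, read by sulforhodamine B assay, with a stated time of 72 h; on this read-out higher numbers stand for weaker inhibition of growth and lower numbers for stronger inhibition of growth:

Compound 1, `O=C(Nc1ccccc1C(F)(F)F)C1CCc2ccccc2N1`, gives 56800 nM.
Compound 2, `O=C(Nc1ccccc1C(F)(F)F)C1CCc2ccccc2N1C(=O)c1cccc(Cl)c1`, gives 292 nM.
Compound 3, `O=C(Nc1ccccc1O)C1CCc2ccccc2N1`, gives 2230 nM.

Compound 1 is the shared starting point. Compound 2 differs from compound 1 in one place, ((3-chlorophenyl)carbonyl in place of hydrogen on a nitrogen on an aromatic ring in a ring), and that difference goes with a large step: a 190-fold lower number from compound 1 to compound 2 (2.29 log units; beyond the scatter). Compound 3 arises from compound 1 through a different change, (hydroxy in place of trifluoromethyl on an aromatic carbon), which also made a large step: a 25-fold lower number from compound 1 to compound 3 (1.41 log units; beyond the scatter). Compound 3 thus sits between the other two numbers, and its steps to both compounds lie beyond the scatter of repeated measurements.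

Compound 4, `O=C(Nc1ccccc1O)C1CCc2ccccc2N1C(=O)c1cccc(Cl)c1`, has not been measured in this assay. It differs from compound 3 by (3-chlorophenyl)carbonyl in place of hydrogen on a nitrogen on an aromatic ring in a ring. This is the same change that turned compound 1 into compound 2, made on a core that differs by the hydroxy in place of trifluoromethyl just described. Among the compounds shown it occurs twice in all, and its place is described in the same words both times.

For compound 4 a large downward step from compound 3 is expected, a 110-fold lower number from compound 3 to compound 4 (2.05 log units; beyond the scatter), because a 190-fold lower number from compound 1 to compound 2 (2.29 log units; beyond the scatter) on the related core. On these data alone, whether the full size of that earlier step carries over to a core already bearing the hydroxy group is unknown from these three numbers, so the expectation is somewhat tempered and given a wide range. Compound 4 is therefore estimated at 20 nM, with a likely span from 4 nM to 100 nM in this assay.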

Compound 4, concentration for 50% growth inhibition: 11600 nM
Beside the measured number, compound 4's estimate is 580-fold (2.76 log units) below it; the whole stated range lies below it.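

In this assay, adding the (3-chlorophenyl)carbonyl group to the hydroxy compound gives a 5.2-fold higher number from compound 3 to compound 4 (0.72 log units; beyond the scatter), so the change that strengthened growth inhibition on the trifluoromethyl core weakens it on the hydroxy core, and the two results differ clearly: the same change on two cores in this assay, a 190-fold lower number (2.29 log units; beyond the scatter) from compound 1 to compound 2 and a 5.2-fold higher number (0.72 log units; beyond the scatter) from compound 3 to compound 4, 1000-fold (3.01 log units) apart, beyond the scatter of two such steps. Seen from the other side, hydroxy in place of trifluoromethyl gives a 40-fold higher number from compound 2 to compound 4 (1.60 log units; beyond the scatter) when the (3-chlorophenyl)carbonyl group is present, the opposite direction from the same swap without that group: the same change on two cores in this assay, a 25-fold lower number (1.41 log units; beyond the scatter) from compound 1 to compound 3 and a 40-fold higher number (1.60 log units; beyond the scatter) from compound 2 to compound 4, 1000-fold (3.01 log units) apart, beyond the scatter of two such steps. This shows that in these four compounds the effect of each change depends on the other, so neither step can simply be carried to a new core and added up, but it does not show why this happens or whether the same holds across the wider series.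

The compounds shown leave open how the (3-chlorophenyl)carbonyl change would behave with a methoxy group or an amine in place of the hydroxy, which could show whether the trifluoromethyl pair or the hydroxy pair is the unusual one. They also leave open whether a different group on the same nitrogen, such as acetyl, would show the same reversal.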